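The source may hold more compounds than are shown below. What is called first, only, known or untested is meant among the compounds shown, and "the series" means these compounds.

Compound 1 `COc1ccc(F)cc1CNCCCNc1ccnc2cc(Cc3ccccc3)ccc12`: 7990 nM
Compound 2 `COc1cccc(CNCCCNc2ccnc3cc(-c4ccccc4)ccc23)c1O`: 3210 nM

Both numbers come from an ADME assay on HepG2 cells (Homo sapiens) for cytotoxicity, read by luminescence, CellTiter-Glo and ATP content, with a stated time of 72 h; on this read-out lower numbers stand for an effect already at smaller amounts and higher numbers for an effect only at larger amounts of compound. Here compound 2 gives 3210 nM, the lower of the two numbers, and its gap to compound 1 lies beyond the scatter. Compound 3 `COc1ccc(F)cc1CNCCCNc1ccnc2cc(-c3ccccc3)ccc12` has yet to be measured. Its difference from compound 2 is 5-fluoro-2-methoxyphenyl in place of 2-hydroxy-3-methoxyphenyl on a saturated chain carbon bound to an amine nitrogen, which places 5-fluoro-2-methoxyphenyl in place of 2-hydroxy-3-methoxyphenyl on a saturated chain carbon bound to an amine nitrogen. Among the measured compounds shown here, no measured pair shows this change on its own. However, compound 1 carries the same 5-fluoro-2-methoxyphenyl group on a different core and gives 7990 nM, so a small rise in the number is expected in this assay. The expected change is a 1.6-fold higher number from compound 2 to compound 3 (0.19 log units; within the scatter). For compound 3 the estimated value is 5000 nM, with an expected range of 2000 nM to 12000 nM.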

Compound 3, half-maximal effective concentration: 2960 nM
Beside the measured number, compound 3's estimate is 1.7-fold (0.23 log units) above it; the measured number falls inside the stated range.
By their numbers in this assay, from the lowest: compounds 3 and 2 (each within the scatter of the next); then compound 1.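

In this assay, 5-fluoro-2-methoxyphenyl in place of 2-hydroxy-3-methoxyphenyl on a saturated chain carbon bound to an amine nitrogen gives a 1.1-fold lower number from compound 2 to compound 3 (0.04 log units; within the scatter), so this exchange, which also takes the hydrogen-bond donor count of the group to 0, leaves compound 2 and compound 3 indistinguishable on this read-out. With 5-fluoro-2-methoxyphenyl held fixed, phenyl in place of benzyl on an aromatic carbon gives a 2.7-fold lower number from compound 1 to compound 3 (0.43 log units; beyond the scatter), the only step shown that lies beyond the scatter. No measurement at hand bears on why either step comes out as it does.

Going by these compounds, it remains open whether the exchange on the chain carbon would also read as flat on the core of compound 1, where only 5-fluoro-2-methoxyphenyl appears. The compounds shown also leave open how a pyridine ring at that place, or a longer chain linking the amine nitrogens, would read.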